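Compound 3 and the benzamido change: working notes

This account rests on a few compounds, and the source may have more. Where it says the series, first, only, none or still open, it means among the compounds named here.

Measured so far in a functional assay on MDA-MB-231 cells (Homo sapiens) for inhibition, read by sulforhodamine B assay (on this read-out higher numbers stand for weaker inhibition of growth and lower numbers for stronger inhibition of growth), as follows
- compound 1 `COc1ccccc1CN1CCC=C(CCC(=O)NO)C1=O` gives > 10000 nM as a limit
- compound 2 `O=C(CCC1=CCCN(Cc2ccc(F)cc2)C1=O)NO` gives "not determined" (no result reported) with no result reported

Compound 2 has no number in this assay and so offers no starting value for the next step. Compound 1 sits at a limit of the assay, not at a number (the limit of > 10000 nM in this assay, at which 1 of the 2 values shown sits). Compound 3 `O=C(CCC1=CCCN(Cc2ccc(NC(=O)c3ccccc3)cc2)C1=O)NO` remains unmeasured. The structural change is a single substitution (benzamido in place of fluoro on an aromatic carbon), with benzamido in place of fluoro on an aromatic carbon, para to a large group. For the measured compounds named here, no measured step gives its size, so only a modest shift towards stronger inhibition of growth is expected in this assay, and a result reported only as a limit remains possible. Compound 3 is estimated at 6000 nM (1000 nM to 20000 nM).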

Compound 3, concentration for 50% growth inhibition: 6030 nM
Compound 3: the middle estimate sits 1.0-fold (0.00 log units) below what was measured; measured number inside the range.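

For the compounds shown here, compound 2 has no reported result in this assay, so no step to compound 3 can be read. The compounds shown leave open how far benzamido in place of fluoro on the aromatic carbon shifts inhibition of growth.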